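Replacing methyl with cyano on compound 3

The source may report more compounds than this note shows. Statements on the series, on what has been measured and on what is new or still open speak of the compounds shown alone.

Among the measured compounds shown here, in a functional assay (strain AB) with Danio rerio as the target, read by microscopy, with a stated time of 1 h (a lower number here means that less compound is needed, a higher number that more compound is needed for the effect), compound 3 `CCN1CCc2c(sc(NC(=O)Nc3cccc(C)c3)c2C(N)=O)C1` gives 13000 nM and compound 2 `CCN1CCc2c(sc(NC(=O)Nc3cccc(Cl)c3Cl)c2C(N)=O)C1` gives 17400 nM, the only two numbers so far. Between them lies a 1.3-fold lower number from compound 2 to compound 3 (0.13 log units; within the scatter). Compound 1 `CCN1CCc2c(sc(NC(=O)Nc3ccccc3)c2C(N)=O)C1` gives > 25000 nM, which is a limit of the assay and not a number.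

Compound 4 `CCN1CCc2c(sc(NC(=O)Nc3cccc(C#N)c3)c2C(N)=O)C1` carries cyano in place of methyl on an aromatic carbon, (cyano in place of methyl on an aromatic carbon). For the measured compounds named here, no measured step makes this exchange. The nearest evidence is an at least 1.9-fold lower number from compound 1 to compound 3 (0.28 log units; that floor lies within the scatter), where methyl replaces hydrogen, together with an at least 1.4-fold lower number from compound 1 to compound 2 (0.15 log units; that floor lies within the scatter), where 2,3-dichlorophenyl replaces phenyl. Neither floor goes beyond the scatter, so these steps give no basis for expecting a large change when the methyl of compound 3 is exchanged. The expected step is a 1.2-fold higher number from compound 3 to compound 4 (0.06 log units; within the scatter), which would stay within the scatter. For compound 4 the estimated value is 15000 nM, with an expected range from 7000 nM to 25000 nM.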

Compound 4, half-maximal effective concentration: 10300 nM
Compound 4: the middle estimate sits 1.5-fold (0.16 log units) above what was measured, within the range that was stated.
By their numbers in this assay, from the lowest: compounds 4, 3 and 2 (each within the scatter of the next). At a limit, above all of these: compound 1.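

Cyano and methyl at this place on the aromatic ring cannot be told apart in this assay, with a 1.3-fold lower number from compound 3 to compound 4 (0.10 log units; within the scatter), and 3-cyanophenyl cannot be told apart from 2,3-dichlorophenyl either, with a 1.7-fold lower number from compound 2 to compound 4 (0.23 log units; within the scatter). What is new is that a group at this position now carries a step from the plain phenyl that goes past the scatter, an at least 2.4-fold lower number from compound 1 to compound 4 (0.38 log units; beyond the scatter), whereas the floor of an at least 1.9-fold lower number from compound 1 to compound 3 (0.28 log units; that floor lies within the scatter) did not. That step starts from a limit and not a number, so it gives only a floor: the limit of > 25000 nM in this assay, at which 1 of the 4 values shown sits.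

On these data alone, whether an amine, a carboxylic acid or a longer chain at this position would move the number beyond the scatter of compound 3 and compound 4 remains open. So does whether cyano elsewhere on the ring would read the same.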